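This account rests on a few compounds, and the source may have more. Where it says the series, first, only, none or still open, it means among the compounds named here.

In a functional assay on a cell-free system (plasma, Homo sapiens), with a stated time of 3 min (a lower number here means a stronger inhibitor, a higher number a weaker inhibitor), compound 1 `CC(C)(C)[C@@H](O)C(=O)N1N=CC[C@H]1C(=O)NCc1cc(Cl)ccc1-n1cnnn1` gives 1400 nM. Going by the values given here, compound 2 `CC(C)(C)[C@@H](O)C(=O)N1[C@H](C(=O)NCc2cc(Cl)ccc2-n2cnnn2)C[C@@H]2C[C@@H]21`, which carries a different core but the same acyl group and benzylamide, gives 1500 nM in this assay; the two values lie within the scatter of each other, so neither compound can be placed ahead of the other, and no step between them has been worked out. Compound 3 `CC(C)(C)OC[C@@H](O)C(=O)N1N=CC[C@H]1C(=O)NCc1cc(Cl)ccc1-n1cnnn1` has not yet been measured in this assay. It differs from compound 1 by (tert-butoxy)methyl in place of tert-butyl on a saturated chain carbon bound to a carbonyl carbon and an oxygen on a saturated carbon. Among the compounds with values here, no measured pair in this set shows what such an exchange does, so the expectation rests on compound 1 alone, with the value 1400 nM as the anchor. The step from compound 1 to compound 3 is expected to be small, a 1.4-fold higher number from compound 1 to compound 3 (0.15 log units; within the scatter), and could fall either side of the scatter. Compound 3 is therefore estimated at 2000 nM, within a range from 700 nM to 6000 nM.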

Compound 3, half-maximal inhibitory concentration: 750 nM
Compound 3: middle estimate off by 2.7-fold (0.43 log units), on the high side, and the stated range covers the measured number.
By their numbers in this assay, from the lowest: compounds 3, 1 and 2 (each within the scatter of the next).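

In this assay, going by these compounds alone, the exchange of tert-butyl for (tert-butoxy)methyl on a saturated chain carbon bound to a carbonyl carbon and an oxygen on a saturated carbon gives a 1.9-fold lower number from compound 1 to compound 3 (0.27 log units; within the scatter) and is the first step measured at this position. It shows that this place can take the larger group, with its added oxygen and hydrogen-bond acceptor, without the number leaving the scatter around compound 1. Nothing measured here explains the size of this step.

On these data alone, it remains open whether methoxymethyl, a longer carbon chain, an amine or a carboxylic acid at this position would move the number beyond the scatter. As far as these compounds go, it is also open whether the same exchange on the core of compound 2 would give a similar step.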